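Changing the benzyl ring while the anilino fluorine stays

The source may report more compounds than this note shows. Statements on the series, on what has been measured and on what is new or still open speak of the compounds shown alone.

Compound 1, `N#Cc1c(Nc2cccc([N+](=O)[O-])c2)nc(SCc2cn(Cc3ccccc3Cl)nn2)nc1-c1ccccc1`: in a functional assay on MCF7 cells (Homo sapiens) for inhibition, read by MTT assay, with a stated time of 72 h (on this read-out lower numbers stand for stronger inhibition and higher numbers for weaker inhibition), compound 1 sits at a limit, > 64000 nM.
Compound 2, `N#Cc1c(Nc2ccccc2F)nc(SCc2cn(Cc3ccccc3Cl)nn2)nc1-c1ccccc1`: in this assay compound 2 gives 8060 nM.
Compound 3, `N#Cc1c(Nc2ccc(F)cc2)nc(SCc2cn(Cc3ccccc3Cl)nn2)nc1-c1ccccc1`: in this assay compound 3 gives 19900 nM.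

Compound 2 holds the lowest of the two numbers; the nearest is compound 3, with a 2.5-fold higher number from compound 2 to compound 3 (0.39 log units; beyond the scatter). Compound 1 is known only as a limit (the limit of > 64000 nM in this assay, at which 1 of the 3 values shown sits). Compound 4, `Cc1ccc(Cn2cc(CSc3nc(Nc4ccccc4F)c(C#N)c(-c4ccccc4)n3)nn2)cc1`, differs from compound 2 in 4-methylphenyl in place of 2-chlorophenyl on a saturated chain carbon bound to an aromatic nitrogen. The measured steps, an at least 7.9-fold lower number from compound 1 to compound 2 (0.89 log units; beyond the scatter), an at least 3.2-fold lower number from compound 1 to compound 3 (0.50 log units; beyond the scatter) and a 2.5-fold higher number from compound 2 to compound 3 (0.39 log units; beyond the scatter), all alter the aryl on the nitrogen, not the benzyl group; none bears on this change, so no step beyond the scatter is expected in this assay. Compound 4 is therefore estimated at 9000 nM (range 3000 nM to 30000 nM), an expected step of a 1.1-fold higher number from compound 2 to compound 4 (0.05 log units; within the scatter).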

Compound 4, half-maximal inhibitory concentration: > 64000 nM
Compound 4: a limit, no number; the forecaster's own chance of this, stated with the estimate: 10%; middle value at least 7.1-fold (0.85 log units) away from the limit.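

Going by these compounds alone, the benzyl group on the triazole is therefore not a neutral position: 2-chlorobenzyl to 4-methylbenzyl gives an at least 7.9-fold higher number from compound 2 to compound 4 (0.89 log units; beyond the scatter), a step the earlier compounds, which varied only the aryl on the nitrogen, could not reveal. Compound 4 is a limit and not a number, so the full size of this step stays unknown: the limit of > 64000 nM in this assay, at which 2 of the 4 values shown sit.

The compounds shown do not separate the loss of the chlorine from the arrival of the methyl. As far as these compounds go, how a plain benzyl or a pyridylmethyl group would read at this place also remains open.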